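The source may report more compounds than this note shows. Statements on the series, on what has been measured and on what is new or still open speak of the compounds shown alone.

Measured compounds: compound 1 `O=C(Nc1cc(-c2ccccc2)nn1-c1ccccc1)c1ccccc1Cl`, compound 2 `O=C(Nc1cc(-c2ccccc2)nn1-c1ccccc1)c1cccc(Cl)c1`, compound 3 `O=C(Nc1cc(-c2ccccc2)nn1-c1ccccc1)c1cccc(F)c1`.

In an assay on CHO cells with metabotropic glutamate receptor 5 (Homo sapiens) as the target (a higher number here means that more compound is needed for the effect, a lower number that less compound is needed), compound 1 gives 2500 nM, compound 2 gives 40 nM and compound 3 gives 20 nM. For the measured compounds named here, compound 3 sits at the low end of the numbers so far: the step of a 2.0-fold lower number from compound 2 to compound 3 (0.30 log units; within the scatter), the step of a 130-fold lower number from compound 1 to compound 3 (2.10 log units; beyond the scatter). Compound 4 `O=C(Nc1cc(-c2ccccc2)nn1-c1ccccc1)c1ccc(Cl)cc1` carries 4-chlorophenyl in place of 3-fluorophenyl on a carbonyl carbon. Going by the values given here, no measured step covers a 4-chlorophenyl. Among the compounds with values here, the steps that bear on it are a 63-fold lower number from compound 1 to compound 2 (1.80 log units; beyond the scatter) and a 130-fold lower number from compound 1 to compound 3 (2.10 log units; beyond the scatter), both large, which show that moving the halogen around the ring can change this assay sharply, whereas a 2.0-fold lower number from compound 2 to compound 3 (0.30 log units; within the scatter) shows that exchanging chloro for fluoro hardly matters. Compound 4 is therefore expected at 100 nM (range 15 nM to 800 nM), an estimated 5.0-fold higher number from compound 3 to compound 4 (0.70 log units; beyond the scatter), with wide uncertainty.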

Compound 4, half-maximal effective concentration: 20 nM
For compound 4 the middle estimate is 5.0-fold (0.70 log units) above the measured one, and the stated range covers the measured number.
By their numbers in this assay, from the lowest: compounds 3, 4 and 2 (each within the scatter of the next); then compound 1.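

In this assay the 4-chlorophenyl reads as no change at the digits printed from compound 3 to compound 4 (within the scatter) against the 3-fluorophenyl and as a 2.0-fold lower number from compound 2 to compound 4 (0.30 log units; within the scatter) against the 3-chlorophenyl, so the shift of chloro from the 3-chlorophenyl to the 4-chlorophenyl stays within the scatter. Only the 2-chlorophenyl stands apart, with a 130-fold lower number from compound 1 to compound 4 (2.10 log units; beyond the scatter) and a large step. No evidence at hand accounts for these readings.

Open, going by these compounds, is how the unsubstituted phenyl reads at this carbonyl carbon. Also open, on these data alone, is whether a 4-fluorophenyl, a 4-aminophenyl or a 4-carboxyphenyl would read like the 4-chlorophenyl.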